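The source may hold more compounds than are shown below. What is called first, only, known or untested is meant among the compounds shown, and "the series" means these compounds.

Measured compounds in a functional assay on A-375 cells (Homo sapiens) for cytotoxicity, read by MTT assay, with a stated time of 48 h; on this read-out higher numbers stand for weaker inhibition and lower numbers for stronger inhibition:
compound 1 `CC(=O)/C=C1\C[C@H]2SC(C)(C)[C@H](C(=O)OC(c3ccccc3)c3ccccc3)N2C1=O`, > 100000 nM
compound 2 `CC1(C)S[C@@H]2/C(=C\C(=O)c3ccc(C(F)(F)F)cc3)C(=O)N2[C@H]1C(=O)OC(c1ccccc1)c1ccccc1`, 26700 nM
compound 3 `CC1(C)[C@H](C(=O)OC(c2ccccc2)c2ccccc2)N2C(=O)/C(=C/C(=O)c3ccc([N+](=O)[O-])cc3)[C@H]2S1(=O)=O`, 76700 nM

Compound 1 reaches only the limit of this assay, (the limit of > 100000 nM in this assay, at which 1 of the 3 values shown sits), and so carries no number. Of the two numbers shown, compound 2 has the lower one; compound 3 gives a higher number in this assay, and that gap is beyond the scatter. All three compounds share the same core and differ in the group carried by the enone side chain and in the state of the sulfur.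

Compound 4 `CC1(C)S[C@@H]2/C(=C\C(=O)c3ccc(Cl)cc3)C(=O)N2[C@H]1C(=O)OC(c1ccccc1)c1ccccc1` has not yet been measured in this assay. It differs from compound 2 by chloro in place of trifluoromethyl on an aromatic carbon. For the measured compounds named here, no pair of measured compounds differs in this one place, so the size of this step is unknown. Compound 4 keeps the aryl ketone that compound 2 and compound 3 carry, whereas compound 1 carries a methyl ketone. The expectation is a step of a 1.1-fold higher number from compound 2 to compound 4 (0.05 log units; within the scatter) of no clear size beyond the scatter. Compound 4 is therefore estimated at 30000 nM, within 12000 nM to 80000 nM.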

Compound 4, half-maximal inhibitory concentration: 48600 nM
The estimate for compound 4 lay 1.6-fold (0.21 log units) below the measured number, within the range that was stated.
By their numbers in this assay, from the lowest: compounds 2, 4 and 3 (each within the scatter of the next, the first and the last beyond it). At a limit, above all of these: compound 1.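

In this assay, the aromatic carbon para to a large group gets its first one-place read: a 1.8-fold higher number from compound 2 to compound 4 (0.26 log units; within the scatter), for chloro in place of trifluoromethyl. At this place, on the aryl ketone, this read-out does not tell the two groups apart, although one group is a single atom and the other a carbon carrying three fluorines. No measured property shown here bears on this step.

Compound 3 carries a nitro group but also differs in the state of the sulfur, so its step, like that of the methyl ketone compound 1, cannot be read. From the compounds shown here alone, whether any group at this place moves the number beyond the scatter remains open, for example an amine, a carboxylic acid or a plain hydrogen.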